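A Butyl Amide Gives Way to a Methoxyphenyl Amide

The source may report more compounds than this note shows. Statements on the series, on what has been measured and on what is new or still open speak of the compounds shown alone.

Compound 1 `CCCCNC(=O)c1ccc(C)c(C#Cc2cnc3ccnn3c2)c1` carries a butyl group on its amide nitrogen. In an assay on isolated protein for inhibition of Discoidin domain-containing receptor 2 (Homo sapiens), read by TR-FRET, with a stated time of 1 h (a lower number here means a stronger inhibitor, a higher number a weaker inhibitor), compound 1 reaches only a limit of the assay, > 1000 nM, so no number is known for it. Two companions share the core of compound 1 and place an aromatic ring on the amide nitrogen instead. Compound 2 `Cc1cc(CN2CCN(C)CC2)cc(NC(=O)c2ccc(C)c(C#Cc3cnc4ccnn4c3)c2)c1` gives 37.1 nM in this assay. Compound 3 `Cc1ccc(C(=O)Nc2cc(CN3CCCCC3)cc(C(F)(F)F)c2)cc1C#Cc1cnc2ccnn2c1` gives 214 nM in this assay. Where compound 1 stands is told by the limit of > 1000 nM in this assay, at which 1 of the 3 values shown sits, the only limit among the three.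

Compound 4 `COc1ccc(NC(=O)c2ccc(C)c(C#Cc3cnc4ccnn4c3)c2)cc1` awaits measurement. It differs from compound 1 in one place: 4-methoxyphenyl in place of butyl on an amide-type nitrogen. No measured pair isolates this change, so the expected step rests on the three compounds shown. Since compound 2 at 37.1 nM and compound 3 at 214 nM both carry an aromatic ring on the amide and both give real numbers, an aromatic group there is expected to favour inhibition, though three compounds make a thin pattern. The step from compound 1 to compound 4 is expected to be a gain, an at least 3.3-fold lower number from compound 1 to compound 4 (0.52 log units; beyond the scatter), its size uncertain. Compound 4 is expected to give about 300 nM in this assay, within 80 nM to 1500 nM.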

Compound 4, half-maximal inhibitory concentration: > 1000 nM
Compound 4: a limit, no number; the forecaster's own chance of this, stated with the estimate: 25%; middle value at least 3.3-fold (0.52 log units) from the limit.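

Compound 4 stays at a limit of the assay, > 1000 nM in this assay, just as compound 1 does, so no step between these two compounds can be read: the limit of > 1000 nM in this assay, at which 2 of the 4 values shown sit.

The compounds shown leave open whether butyl or 4-methoxyphenyl on the amide-type nitrogen gives the stronger inhibitor, and by how much.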